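Adding a second hydroxy group to compound 3

The source may report more compounds than this note shows. Statements on the series, on what has been measured and on what is new or still open speak of the compounds shown alone.

Three compounds with a shared core have numbers in a functional assay on HeLa cells (Homo sapiens) for cytotoxicity, read by MTT assay (a lower number here means a stronger inhibitor, a higher number a weaker inhibitor), so far. Compound 1 (`COc1ccc(/C=C/C(=O)c2c(OC)cc(O)c(CC=C(C)C)c2O)cc1OC`) gives 17100 nM and compound 2 (`COc1cc(OC)c(C(=O)/C=C/c2ccc(O)cc2)c(O)c1CC=C(C)C`) gives 11800 nM (these two values lie within the scatter of each other). Compound 3 (`COc1cc(O)c(CC=C(C)C)c(O)c1C(=O)/C=C/c1cccc(O)c1`) gives 4800 nM and holds the lowest number of the three, so it is the strongest inhibitor here, with its distance to both of the others beyond the scatter.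

Compound 4 (`COc1cc(O)c(CC=C(C)C)c(O)c1C(=O)/C=C/c1cc(O)cc(O)c1`) differs from compound 3 in one place (hydroxy in place of hydrogen on an aromatic carbon), with hydroxy in place of hydrogen on an aromatic carbon, turning 3-hydroxyphenyl into 3,5-dihydroxyphenyl. Among the measured compounds shown here, no two measured compounds differ in only one place, so the series gives no direct measure of what this change does in this assay. The three values span only a narrow band, and with so little to go on, the expectation stays anchored on compound 3 (4800 nM) with no firm direction. The estimated step of a 1.1-fold higher number from compound 3 to compound 4 (0.06 log units; within the scatter) is expected to stay within the scatter, with a slight lean towards a weaker number. For compound 4 the expected value is 5500 nM (estimated range 2000 nM to 14000 nM).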

Compound 4, half-maximal inhibitory concentration: 3200 nM
Estimate against measurement, compound 4: 1.7-fold (0.24 log units) above; the range from low to high includes it.
By their numbers in this assay, from the lowest: compounds 4 and 3 (each within the scatter of the next); then compounds 2 and 1 (each within the scatter of the next).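

Working note on the position: in this assay, the only pair differing in one place gives a 1.5-fold lower number from compound 3 to compound 4 (0.18 log units; within the scatter) when hydroxy replaces hydrogen on the aromatic carbon meta to a hydroxy group and meta to a large group. Among the compounds shown here, the earlier compounds offered no such pair, so this is the first direct reading of a single change, and it shows that going from 3-hydroxyphenyl to 3,5-dihydroxyphenyl leaves the number indistinguishable from that of compound 3 within the usual scatter. No measurement in hand bears on why the step has this size.

Still open, as far as these compounds go, is whether a different kind of group at this same ring carbon, such as an amine or a carboxylic acid, would carry the number beyond the scatter in either direction. Steps from compound 1 and compound 2 to the other compounds cannot be read, since those pairs differ in more than one place, so whether the same hydroxy change behaves alike on the other substitution patterns also remains unanswered.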